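Moving the Chlorine and Trifluoromethyl on the Urea Aryl

The compounds below may be only part of what the source reports. "The series", "measured", "known", "first", "only" and "open" are said of these compounds alone.

Measured compounds:
compound 1, `CC(NC(=O)C#Cc1ccc(NC(=O)Nc2cc(C(F)(F)F)ccc2Cl)cc1)c1ccccc1`, 30500 nM
compound 2, `CC(NC(=O)c1cccc(-c2ccc(NC(=O)Nc3ccc(Cl)c(C(F)(F)F)c3)cc2)c1)c1ccccc1`, 5170 nM
compound 3, `CNC(=O)/C=C/c1ccc(NC(=O)Nc2ccc(Cl)c(C(F)(F)F)c2)cc1`, 20900 nM

In a functional assay on A-375 cells (Homo sapiens) for inhibition, read by MTT assay, with a stated time of 120 h (on this read-out higher numbers stand for weaker inhibition and lower numbers for stronger inhibition), compound 1 gives the highest of the three numbers. Its value and that of compound 3 lie within the scatter of each other, while compound 2 sits clearly lower, beyond the scatter.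

Compound 4, `CC(NC(=O)C#Cc1ccc(NC(=O)Nc2ccc(Cl)c(C(F)(F)F)c2)cc1)c1ccccc1`, differs from compound 1 in one place: 4-chloro-3-(trifluoromethyl)phenyl in place of 2-chloro-5-(trifluoromethyl)phenyl on an amide-type nitrogen. Compounds 2 and 3 already carry this same 4-chloro-3-(trifluoromethyl)phenyl group, and their values in this assay are lower than that of compound 1. A step toward stronger inhibition, of moderate size, is therefore expected for compound 4, as a 3.4-fold lower number from compound 1 to compound 4 (0.53 log units; beyond the scatter). The estimate for compound 4 is 9000 nM, within a range from 2500 nM to 28000 nM.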

Compound 4, half-maximal inhibitory concentration: 16800 nM
Estimate against measurement, compound 4: 1.9-fold (0.27 log units) below, and the stated range covers the measured number.
By their numbers in this assay, from the lowest: compound 2; then compounds 4, 3 and 1 (each within the scatter of the next).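

Putting 4-chloro-3-(trifluoromethyl)phenyl in place of 2-chloro-5-(trifluoromethyl)phenyl on the amide-type nitrogen gives, in this assay, a 1.8-fold lower number from compound 1 to compound 4 (0.26 log units; within the scatter), a step within the scatter. With the rest of the molecule held fixed, this reshuffling of the same atoms therefore has no clear effect on the read-out, which compound 2 and compound 3, differing from compound 1 elsewhere as well, could not show. Nothing measured here offers an explanation for this result. Going by these compounds, whether a plain phenyl or a 4-methoxyphenyl at this place would shift the number beyond the scatter stays open. So does whether the same swap would behave alike on the core of compound 2.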